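Chain hydroxylation in a series sitting at the assay limit

The source may hold more compounds than are shown below. What is called first, only, known or untested is meant among the compounds shown, and "the series" means these compounds.

Compound 1 `CCCn1c(N)c(-c2nc3ccccc3[nH]2)c2nc(C#N)c(C#N)nc21`, compound 2 `N#Cc1nc2c(-c3nc4ccccc4[nH]3)c(N)n(CCO)c2nc1C#N` and compound 3 `CCCCn1c(N)c(-c2nc3ccccc3[nH]2)c2nc(C#N)c(C#N)nc21` share one core and differ only in the chain on the aromatic nitrogen. In a functional assay on cells (Homo sapiens) for antiproliferative activity, read by MTT assay, with a stated time of 48 h (a higher number here means a weaker inhibitor, a lower number a stronger inhibitor), compound 1 gives only a limit, > 50000 nM. Compound 2 likewise gives only a limit in this assay, > 50000 nM. For compound 3 the result in this assay is again a limit, > 50000 nM. The change from compound 1 to compound 2 is hydroxy in place of methyl on a saturated chain carbon, two bonds along the chain from an aromatic nitrogen; its step, a step that the two limits leave unreadable from compound 1 to compound 2, cannot be sized because of the limit of > 50000 nM in this assay, at which 3 of the 3 values shown sit. Compound 4 `N#Cc1nc2c(-c3nc4ccccc4[nH]3)c(N)n(CCCO)c2nc1C#N` is not yet measured; it differs from compound 3 by hydroxy in place of methyl on a saturated chain carbon, three bonds along the chain from an aromatic nitrogen, the same kind of change but three rather than two bonds along the chain, and the two cores differ by methyl in place of hydrogen on a saturated chain carbon, three bonds along the chain from an aromatic nitrogen. Since all three neighbours sit at the limit of > 50000 nM in this assay, at which 3 of the 3 values shown sit, the expected step is a step that the limit leaves unreadable from compound 3 to compound 4, most likely again unreadable. Compound 4 is estimated at 70000 nM.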

Compound 4, half-maximal inhibitory concentration: > 50000 nM
Compound 4: only a limit was reported; the forecaster's own chance of this, stated with the estimate: 85%; the middle value is on the limit's open side.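

No step between compound 4 and compound 1, compound 2 or compound 3 can be read in this assay, because each result is only a limit: the limit of > 50000 nM in this assay, at which 4 of the 4 values shown sit.

As far as these compounds go, whether any of these chain changes, such as butyl to 3-hydroxypropyl, alters activity remains open.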